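Swapping methyl for ethynyl on the anilide ring

A few compounds are considered here, and "the series" means these few. Any claim that something is new, unique, unknown or untested is made for them only; others in the source may bear on it.

compound 1 `O=C(CCc1cccc2c1B(O)OC2)Nc1ccc(I)cc1`: 51000 nM
compound 2 `Cc1ccc(NC(=O)CCc2cccc3c2B(O)OC3)cc1`: 860 nM

In a functional assay on SK-OV-3 cells (Homo sapiens) for antiproliferative activity, read by MTT assay, with a stated time of 72 h (on this read-out lower numbers stand for stronger inhibition and higher numbers for weaker inhibition), compound 2 holds the lower of the two numbers, at 860 nM, while compound 1 stands at 51000 nM. Compound 3 `C#Cc1ccc(NC(=O)CCc2cccc3c2B(O)OC3)cc1` has not yet been measured. It carries ethynyl in place of methyl on an aromatic carbon, para to a large group (ethynyl in place of methyl on an aromatic carbon). Within the data shown here, one measured step bears on this change, made on the same carbon: a 59-fold lower number from compound 1 to compound 2 (1.77 log units; beyond the scatter), a large step on swapping iodo for methyl. Among the measured compounds shown here, the group here can thus move the number a long way in this assay, yet no measured compound carries ethynyl. A moderate rise is expected, leaving the number between the two measured values and nearer the lower one. The expected change is a 2.3-fold higher number from compound 2 to compound 3 (0.37 log units; beyond the scatter). For compound 3 the estimate is 2000 nM, with an expected range from 400 nM to 10000 nM.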

Compound 3, half-maximal inhibitory concentration: 6300 nM
For compound 3 the middle estimate is 3.2-fold (0.50 log units) below the measured one; the range from low to high includes it.
By their numbers in this assay, from the lowest: compound 2; then compound 3; then compound 1.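

In this assay ethynyl in place of methyl gives a 7.3-fold higher number from compound 2 to compound 3 (0.86 log units; beyond the scatter) and ethynyl in place of iodo gives an 8.1-fold lower number from compound 1 to compound 3 (0.91 log units; beyond the scatter) on the same aromatic carbon. Among these compounds, the single earlier step could not separate a favourable methyl from an unfavourable iodo, but now a second group also gives a higher number than methyl, with ethynyl falling between the other two, so this position tells the three groups apart beyond the scatter. Nothing measured here accounts for this order.

The compounds shown leave open whether any other group on this carbon, such as ethyl, methoxy, chloro or an amine, would match or improve on methyl. They also leave open whether the same order of methyl, ethynyl and iodo would hold on a different core.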